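Cyclobutylmethyl ester on the thiophene analogue

The compounds below may be only part of what the source reports. "The series", "measured", "known", "first", "only" and "open" are said of these compounds alone.

Of the compounds shown here, three of the shared core have been measured in an assay on membranes from CHO cells for displacement of a labelled ligand from adenosine receptor A1 (Homo sapiens), read by scintillation counting, with a stated time of 60 min, tested at 1 uM; a lower number here means less inhibition, a higher number more inhibition at the concentration tested (going by the name of the read-out). Compound 1 `CC1=C(C(=O)OCC2CC2)C(c2ccoc2)NC(=O)N1` gives 29% in this assay. Compound 2 `CC1=C(C(=O)OCC2CCC2)C(c2ccoc2)NC(=O)N1` differs from compound 1 by cyclobutyl in place of cyclopropyl on a saturated chain carbon bound to an oxygen next to a carbonyl group; in this assay compound 2 gives 46%, and the step is a number 17 percentage points higher from compound 1 to compound 2 (beyond the scatter). Compound 3 `CC1=C(C(=O)OCC2CC2)C(c2ccsc2)NC(=O)N1` differs from compound 1 by thiophen-3-yl in place of furan-3-yl on a saturated ring carbon; in this assay compound 3 gives 39%, and the step is a number 10 percentage points higher from compound 1 to compound 3 (within the scatter). Compound 2 and compound 3 lie within the scatter of each other.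

Compound 4 `CC1=C(C(=O)OCC2CCC2)C(c2ccsc2)NC(=O)N1` is not yet measured. It differs from compound 3 by cyclobutyl in place of cyclopropyl on a saturated chain carbon bound to an oxygen next to a carbonyl group, the same change that is made from compound 1 to compound 2, at the same place. Going by the values given here, only one measured instance of this change exists, so carrying it onto the thiophen-3-yl core rests on one step alone and on the value of compound 3. Beside the measured step of a number 17 percentage points higher from compound 1 to compound 2 (beyond the scatter), the expected step for compound 4 is a number 17 percentage points higher from compound 3 to compound 4 (beyond the scatter). The estimate for compound 4 in this assay is 56%, expected to fall between 40% and 70%.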

Compound 4, a percentage reported as inhibition, at one concentration (the size of the read-out at that concentration, not a potency): 48%
Beside the measured number, compound 4's estimate is 8 percentage points above it; measured number inside the range.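

In this assay, cyclobutyl in place of cyclopropyl on the thiophen-3-yl core gives a number 9 percentage points higher from compound 3 to compound 4 (within the scatter), and the two instances of this change cannot be told apart: the same change on two cores in this assay, a number 17 percentage points higher (beyond the scatter) from compound 1 to compound 2 and a number 9 percentage points higher (within the scatter) from compound 3 to compound 4, 8 percentage points apart, within the scatter of two such steps. Thiophen-3-yl in place of furan-3-yl on the cyclobutyl side gives a number 2 percentage points higher from compound 2 to compound 4 (within the scatter), and this change also reads the same on both cores: the same change on two cores in this assay, a number 10 percentage points higher (within the scatter) from compound 1 to compound 3 and a number 2 percentage points higher (within the scatter) from compound 2 to compound 4, 8 percentage points apart, within the scatter of two such steps. Across these four compounds, neither change shows a dependence on the core, but this does not prove that the steps are independent of it or fix their size, as only two instances of each exist and the cyclobutyl step lies beyond the scatter on one core and within it on the other.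

Still open, as far as these compounds go, is whether the ester side can go beyond cyclobutyl, for instance to cyclopentyl, a longer chain or an amine. Also open, from the compounds shown here alone, is whether phenyl on the saturated ring carbon would follow the same steps, and how these readings at a single concentration relate to potency.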